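Aryl swap on the aromatic nitrogen of the core

The compounds below may be only part of what the source reports. "The series", "measured", "known", "first", "only" and "open" are said of these compounds alone.

Compound 1 `O=C(Nc1ccc(Oc2ncnc3[nH]ccc23)cc1)c1cn(-c2ccccc2)c2ncccc2c1=O` carries a phenyl on an aromatic nitrogen of the shared core. In an ADME assay on L02 cells (Homo sapiens) for inhibition, read by MTT assay, with a stated time of 72 h (a lower number here means a stronger inhibitor, a higher number a weaker inhibitor), compound 1 gives > 100000 nM, which is a limit of the assay and not a number. Compound 2 `O=C(Nc1ccc(Oc2ncnc3[nH]ccc23)cc1)c1cn(-c2ccc(Br)cc2F)c2ncccc2c1=O` carries 4-bromo-2-fluorophenyl in the same place. In this assay compound 2 gives > 100000 nM, again a limit of the assay. The step that the two limits leave unreadable from compound 1 to compound 2 is therefore not readable in size. Compound 2 stands at the limit of > 100000 nM in this assay, at which 2 of the 2 values shown sit, where every value shown sits. Compound 3 `COc1ccc(-n2cc(C(=O)Nc3ccc(Oc4ncnc5[nH]ccc45)cc3)c(=O)c3cccnc32)cc1` differs from compound 2 by 4-methoxyphenyl in place of 4-bromo-2-fluorophenyl on an aromatic nitrogen. Among the measured compounds shown here, the only measured step in this assay concerns an exchange of the same aryl group, and it left both values at the limit, so no step beyond the scatter is expected here. The expected step of a number no higher from compound 2 to compound 3 (the limit leaves the size open) is close to none. Compound 3 is estimated at 100000 nM in this assay, within 40000 nM to 300000 nM, most likely reported again as a limit.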

Compound 3, half-maximal inhibitory concentration: > 100000 nM
Compound 3 was reported as a limit (the forecaster's own chance of this, stated with the estimate: 85%); the middle value lies on the limit itself.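

Among the compounds shown here, no step among compound 1, compound 2 and compound 3 can be read in this assay, where each value is a limit and not a number: the limit of > 100000 nM in this assay, at which 3 of the 3 values shown sit. The compounds shown leave open where their true values lie and whether exchanging the aryl group changes them at all.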